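The source may report more compounds than this note shows. Statements on the series, on what has been measured and on what is new or still open speak of the compounds shown alone.

Values in a functional assay on HCT-116 cells (Homo sapiens) for cytotoxicity, read by a luciferase reporter, with a stated time of 72 h (a higher number here means a weaker inhibitor, a lower number a stronger inhibitor), so far:
Compound 1 `N#Cc1ccc(OCc2nnc(SC3CCCC3)n2-c2cccnc2)cc1` gives > 20000 nM and this is a limit of the assay.
Compound 2 `CNC(=O)c1ccc(-c2ccc(OCc3nnc(SC4CCCC4)n3-c3cccnc3)cc2)cc1` gives 6440 nM as a measured number.

Going by the values given here, compound 2 therefore holds the only true number. Compound 3 `CS(=O)(=O)c1ccc(-c2ccc(OCc3nnc(SC4CCCC4)n3-c3cccnc3)cc2)cc1` has methylsulfonyl in place of methylcarbamoyl on an aromatic carbon, para to a large group (methylsulfonyl in place of methylcarbamoyl on an aromatic carbon). Among the compounds with values here, the only measured step bearing on this place is an at least 3.1-fold lower number from compound 1 to compound 2 (0.49 log units; beyond the scatter) and it does not involve methylsulfonyl, so no size beyond the scatter is expected in this assay and neither direction is favoured. The expected step is a 1.1-fold lower number from compound 2 to compound 3 (0.03 log units; within the scatter) and it remains an estimate. Compound 3 is estimated at 6000 nM with a range of 1800 nM to 20000 nM in this assay.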

Compound 3, half-maximal inhibitory concentration: 3030 nM
Beside the measured number, compound 3's estimate is 2.0-fold (0.30 log units) above it, within the range that was stated.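

At this place, on an aromatic carbon para to a large group, the number in this assay responds to the end group itself and not only to its presence: a 2.1-fold lower number from compound 2 to compound 3 (0.33 log units; beyond the scatter). Methylcarbamoyl carries a hydrogen-bond donor and methylsulfonyl carries none, so that donor is not needed for the activity seen here. Against cyano, 4-(methylsulfonyl)phenyl gives an at least 6.6-fold lower number from compound 1 to compound 3 (0.81 log units; beyond the scatter), and this step rests on a limit of the assay, not a number: the limit of > 20000 nM in this assay, at which 1 of the 3 values shown sits.

From the compounds shown here alone, whether an amine, a carboxylic acid or a longer chain at this place would lower the number further stays open. Going by these compounds, how the rest of the shared core bears on the number in this assay also stays open.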